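This account rests on a few compounds, and the source may have more. Where it says the series, first, only, none or still open, it means among the compounds named here.

Three compounds sharing one core have been run in a functional assay on L1210 cells (Mus musculus) for inhibition, read by MTT assay; on this read-out higher numbers stand for weaker inhibition and lower numbers for stronger inhibition. Compound 1 `CCCCNC(=O)N1CC1C#N` gives 12000 nM in this assay. Compound 2 `N#CC1CN1C(=O)Nc1cccnc1` gives 11000 nM, and compound 3 `N#CC1CN1C(=O)NC1CCCCC1` gives 7400 nM. Compound 1 carries the highest of the three numbers, yet its gap to compound 2 and its gap to compound 3 both lie within the scatter of repeated measurements, so these data do not separate the three.

Compound 4 `CC(C)(C)NC(=O)N1CC1C#N` has not been measured. It differs from compound 1 in one place: tert-butyl in place of butyl on an amide-type nitrogen. The two have the same atoms, joined differently. Among the measured compounds shown here, no pair among the measured compounds differs in a single place, so there is no measured step from which the effect of such a change could be read, and nothing in the numbers so far points in either direction. The expected step of no change at the digits printed from compound 1 to compound 4 (within the scatter) is therefore none beyond the scatter. Compound 4 is estimated at 12000 nM, with a range from 5000 nM to 30000 nM.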

Compound 4, half-maximal inhibitory concentration: 132000 nM
Beside the measured number, compound 4's estimate is 11-fold (1.04 log units) below it; the measured number lies above the stated range.
By their numbers in this assay, from the lowest: compounds 3, 2 and 1 (each within the scatter of the next); then compound 4.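

In this assay, tert-butyl in place of butyl on an amide-type nitrogen gives an 11-fold higher number from compound 1 to compound 4 (1.04 log units; beyond the scatter), which means weaker inhibition and shows that this position does not tolerate every group of this size. Butyl and tert-butyl have the same count of heavy atoms and the same atoms overall, so the step separates two compounds by the way the carbons are joined, not by what they contain. Nothing available here accounts for the size of this step.

From the compounds shown here alone, whether the step belongs to tert-butyl alone or appears with branching more generally stays open; isopropyl, isobutyl and sec-butyl on the same nitrogen would mark out that boundary. Going by these compounds, how a longer chain such as hexyl compares with butyl at this position also remains unknown.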